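Removing the pyridin-4-yl group from the oxazole-bearing indole

This account rests on a few compounds, and the source may have more. Where it says the series, first, only, none or still open, it means among the compounds named here.

Compounds measured so far in a functional assay on LNCaP cells (Homo sapiens) for cytotoxicity, read by MTT assay, with a stated time of 48 h; a higher number here means a weaker inhibitor, a lower number a stronger inhibitor:
compound 1 `Cc1nc(-c2c[nH]c3ccccc23)co1`, 316000 nM
compound 2 `c1ccc2c(-c3coc(-c4ccncc4)n3)c[nH]c2c1`, 238000 nM

Among the measured compounds shown here, compound 2 has the lowest of the two numbers in this assay, with compound 1 as its only neighbour, a difference within the scatter. For the measured compounds named here, the one step on record, a 1.3-fold lower number from compound 1 to compound 2 (0.12 log units; within the scatter), replaced methyl at the same carbon and changed little. Compound 3 `c1ccc2c(-c3cocn3)c[nH]c2c1` differs from compound 2 by hydrogen in place of pyridin-4-yl on an aromatic carbon. Going by the values given here, since the only measured exchange at this carbon did nothing beyond the scatter, the expected step is a 1.3-fold higher number from compound 2 to compound 3 (0.10 log units; within the scatter), no real change. Compound 3 is therefore estimated at 300000 nM, within 150000 nM to 600000 nM.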

Compound 3, half-maximal inhibitory concentration: 382000 nM
Beside the measured number, compound 3's estimate is 1.3-fold (0.10 log units) below it, within the range that was stated.
By their numbers in this assay, from the lowest: compounds 2, 1 and 3 (each within the scatter of the next).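

With hydrogen on this aromatic carbon, this assay gives a 1.6-fold higher number from compound 2 to compound 3 (0.21 log units; within the scatter) and a 1.2-fold higher number from compound 1 to compound 3 (0.08 log units; within the scatter) and thus no real change from either substituted compound. Among the compounds shown here, the earlier pair compared only two groups, whereas compound 3 adds the unsubstituted reference: at this position, neither pyridin-4-yl nor methyl can be told apart from hydrogen. Nothing available explains this lack of separation.

From the compounds shown here alone, whether an amine, a carboxylic acid or a longer chain on this carbon would move the number beyond the scatter stays open. So does whether a change elsewhere on the shared core would do so.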